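The compounds below may be only part of what the source reports. "The series", "measured", "known", "first", "only" and "open" are said of these compounds alone.

Measured compounds in a functional assay on MCF7 cells (Homo sapiens) for inhibition, read by sulforhodamine B assay; a lower number here means a stronger inhibitor, a higher number a weaker inhibitor:
compound 1 `O=C1C(Nc2ccccc2)=CC(=O)c2c1nc1n2[C@H]2OC[C@@H](O)[C@H]2OC1` — > 4000 nM
compound 2 `O=C1C=C(Nc2ccc(C(F)(F)F)cc2)C(=O)c2c1nc1n2[C@H]2OC[C@@H](O)[C@H]2OC1` — > 4000 nM
compound 3 `Cc1ccc(NC2=CC(=O)c3nc4n(c3C2=O)[C@H]2OC[C@@H](O)[C@H]2OC4)cc1` — 1660 nM.

Compound 1 gives > 4000 nM, which is a limit of the assay, not a number. The value of compound 2 is likewise a limit. Among the compounds with values here, compound 3 gives 1660 nM, and the step of an at least 2.4-fold lower number from compound 2 to compound 3 (0.38 log units; beyond the scatter) is the only measured change, methyl in place of trifluoromethyl on an aromatic carbon. With the limit of > 4000 nM in this assay, at which 2 of the 3 values shown sit, most of the series sits at the edge of the assay.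

Compound 4 `COc1cccc(NC2=CC(=O)c3c(nc4n3[C@H]3OC[C@@H](O)[C@H]3OC4)C2=O)c1` differs from compound 1 by methoxy in place of hydrogen on an aromatic carbon. Within the data shown here, no measured step covers methoxy in place of hydrogen, and compound 1 itself gives only a limit. No direction follows from the data. Compound 4 is expected near the same limit, at 4000 nM within 1500 nM to 10000 nM. The step expected is a number no higher from compound 1 to compound 4 (the limit leaves the size open).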

Compound 4, half-maximal inhibitory concentration: 3830 nM
Compound 4: middle estimate off by 1.0-fold (0.02 log units), on the high side; low and high end bracket the measured number.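

In this assay, compound 4 gives a measured number rather than a limit, so methoxy on this phenyl ring, meta to a large group, brings the series just inside the readable range. Compound 1 gives > 4000 nM, which is a limit of the assay. Methoxy in place of hydrogen therefore reads only as an at least 1.0-fold lower number from compound 1 to compound 4 (0.01 log units; that floor lies within the scatter), and the true size of the step stays open: the limit of > 4000 nM in this assay, at which 2 of the 4 values shown sit.

From the compounds shown here alone, what a carboxylic acid or an amine in the same place would give remains open. So does the effect of a longer chain, such as ethoxy, in place of methoxy.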